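The source may hold more compounds than are shown below. What is called first, only, known or untested is meant among the compounds shown, and "the series" means these compounds.

Of the compounds shown here, two have been tested so far in an ADME assay on HEK-293T cells (Homo sapiens) for cytotoxicity, read by CCK-8 assay, with a stated time of 48 h; a lower number here means a stronger inhibitor, a higher number a weaker inhibitor. Compound 1 `O=C(NCCNS(=O)(=O)c1ccc(-c2ccccc2Oc2ccc([N+](=O)[O-])c([N+](=O)[O-])c2)s1)Nc1cc(C(F)(F)F)cc(C(F)(F)F)c1` gives > 50000 nM, which is a limit and not a number. As far as these compounds go, compound 2 `O=S(=O)(c1sccc1-c1ccccc1Oc1ccc(O)c(O)c1)N1CCN(C(=S)Nc2cc(C(F)(F)F)cc(C(F)(F)F)c2)CC1` gives > 20000 nM, which is also a limit, so its exact position on the scale is unknown.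

Compound 3 `O=[N+]([O-])c1ccc(Oc2ccc(O)c(O)c2)c(-c2ccsc2S(=O)(=O)N2CCN(C(=S)Nc3cc(C(F)(F)F)cc(C(F)(F)F)c3)CC2)c1` differs from compound 2 in one place: nitro in place of hydrogen on an aromatic carbon. A nitro replaces a hydrogen on an aromatic carbon, para to a 3,4-dihydroxyphenoxy group. Going by the values given here, no measured pair of compounds shows what this change does in this assay, so any forecast is uncertain. Compound 2, with its limit of > 20000 nM, is the only starting point, so no step beyond the usual scatter is expected. The expected size of the step that the limit leaves unreadable from compound 2 to compound 3 is an estimate only. Compound 3 is estimated at 30000 nM, with an expected range from 10000 nM to 60000 nM.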

Compound 3, half-maximal inhibitory concentration: > 20000 nM
Compound 3: only a limit was reported; the forecaster's own chance of this, stated with the estimate: 60%; the middle value lies beyond the limit too.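

Compound 2 and compound 3 are each reported only as a limit, and the step between them cannot be read. The compounds shown leave open the exact values of compound 1, compound 2 and compound 3, and whether nitro in place of hydrogen changes the read-out at all.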